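The source may hold more compounds than are shown below. What is called first, only, known or untested is meant among the compounds shown, and "the series" means these compounds.

In an ADME assay on FHC cells (Homo sapiens) for cytotoxicity, read by resazurin assay, with a stated time of 48 h (a higher number here means that more compound is tolerated, a lower number that less compound is tolerated), compound 1 (`COc1ccc(S(=O)(=O)Nc2ccc(-c3nc4cc(NS(=O)(=O)c5ccc(OC)cc5)ccc4o3)cc2)cc1`) gives 57000 nM. Compound 2 (`COc1ccc(S(=O)(=O)Nc2ccc3oc(-c4ccc(NC(=O)c5ccc(Cl)s5)cc4)nc3c2)cc1`) reaches only a limit, > 100000 nM. Among the compounds with values here, the one measured step that bears on the change ahead is an at least 1.7-fold higher number from compound 1 to compound 2 (0.24 log units; that floor lies within the scatter). Compound 3 (`COc1ccc(S(=O)(=O)Nc2ccc3oc(-c4ccc(NS(=O)(=O)c5cc(F)ccc5OC)cc4)nc3c2)cc1`) differs from compound 2 on a nitrogen on an aromatic ring: a group of 12 heavy atoms (7 carbon, 3 oxygen, 1 fluorine, 1 sulfur; one six-membered aromatic ring of carbon only) in place of a group of 8 heavy atoms (5 carbon, 1 oxygen, 1 sulfur, 1 chlorine; one five-membered aromatic ring with 1 hetero atom), on a nitrogen on an aromatic ring. The entering group, like the (4-methoxyphenyl)sulfonyl of compound 1, holds a six-membered aromatic ring of carbon only, so a value near the 57000 nM of compound 1 seems likely. The expected change is modest and downward, an at least 1.6-fold lower number from compound 2 to compound 3 (0.22 log units; that floor lies within the scatter). For compound 3 the estimate is 60000 nM, with an expected range of 25000 nM to 100000 nM.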

Compound 3, half-maximal cytotoxic concentration: > 100000 nM
Compound 3 was reported as a limit; the forecaster's own chance of this, stated with the estimate: 25%; middle value at least 1.6-fold (0.22 log units) from the limit.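

Compound 3 also stands at a limit (> 100000 nM), so a sulfonyl group on this nitrogen need not stay near the value of compound 1. Putting 5-fluoro-2-methoxyphenyl in place of 4-methoxyphenyl on the sulfonyl sulfur gives an at least 1.7-fold higher number from compound 1 to compound 3 (0.24 log units; that floor lies within the scatter) and so does not clearly separate the two compounds. The step from compound 2 to compound 3 cannot be read, because both compounds sit at the same ceiling: the limit of > 100000 nM in this assay, at which 2 of the 3 values shown sit.

On these data alone, how far compound 2 and compound 3 lie beyond that ceiling remains open. So does whether a simple amine or a carboxylic acid-bearing chain on this nitrogen would lower the number.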